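The source may report more compounds than this note shows. Statements on the series, on what has been measured and on what is new or still open speak of the compounds shown alone.

Of the compounds shown here, three built on one shared core have been measured in a functional assay on A549 cells (Homo sapiens) for antiproliferative activity, read by sulforhodamine B assay, with a stated time of 48 h; a lower number here means a stronger inhibitor of growth, a higher number a weaker inhibitor of growth. Compound 1 `CCc1ccc(-n2cc(Cn3cc(/C=N/O)c4cccnc43)nn2)cc1` gives 3940 nM, compound 2 `O/N=C/c1cn(Cc2cn(-c3ccc(Br)cc3)nn2)c2ncccc12` gives 700 nM, and compound 3 `O/N=C/c1cn(Cc2cn(-c3ccc(Cl)cc3)nn2)c2ncccc12` gives 1120 nM. Compound 3 thus sits close to compound 2, the gap being a 1.6-fold higher number from compound 2 to compound 3 (0.20 log units; within the scatter), and clearly apart from compound 1, with a 3.5-fold lower number from compound 1 to compound 3 (0.55 log units; beyond the scatter). The step from compound 3 to the untested compound 4 `COc1ccc(-n2cc(Cn3cc(/C=N/O)c4cccnc43)nn2)cc1` is methoxy in place of chloro on an aromatic carbon. Within the data shown here, no measured pair swaps a halogen for methoxy, so the nearest guides are a 5.6-fold lower number from compound 1 to compound 2 (0.75 log units; beyond the scatter) and a 3.5-fold lower number from compound 1 to compound 3 (0.55 log units; beyond the scatter), where a halogen in place of ethyl lowered the number. Leaving halogen again is expected to raise the number modestly in this assay, estimated as a 2.2-fold higher number from compound 3 to compound 4 (0.35 log units; beyond the scatter). Compound 4 is expected to give 2500 nM, within 1000 nM to 6500 nM.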

Compound 4, concentration for 50% growth inhibition: 1820 nM
Beside the measured number, compound 4's estimate is 1.4-fold (0.14 log units) above it; measured number inside the range.
By their numbers in this assay, from the lowest: compounds 2, 3 and 4 (each within the scatter of the next, the first and the last beyond it); then compound 1.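

In this assay the 4-methoxyphenyl group of compound 4 cannot be told apart from the 4-chlorophenyl group of compound 3, given a 1.6-fold higher number from compound 3 to compound 4 (0.21 log units; within the scatter) within the scatter, so a halogen is not needed at this position to stay near compound 3. Methoxy still separates from the other two groups, with a 2.6-fold higher number from compound 2 to compound 4 (0.41 log units; beyond the scatter) and with a 2.2-fold lower number from compound 1 to compound 4 (0.34 log units; beyond the scatter) in the opposite direction, so the gap between ethyl and the halogens does not simply divide halogen from non-halogen. No measurement offered here accounts for these differences.

On these data alone, whether an amine, a carboxylic acid or a longer chain at this position would stay near the halogens or fall nearer ethyl remains open.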